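The source may report more compounds than this note shows. Statements on the series, on what has been measured and on what is new or still open speak of the compounds shown alone.

In a functional assay on Jurkat cells (Homo sapiens) for inhibition, read by CCK-8 assay, with a stated time of 48 h (on this read-out lower numbers stand for stronger inhibition of growth and higher numbers for weaker inhibition of growth), compound 1 `Cc1ccccc1Nc1nc(Nc2ccccn2)ncc1Cl` gives 20100 nM. Compound 2 `Cc1ccccc1Nc1nc(Nc2ccc(N3CCN(C)CC3)cn2)ncc1Cl` gives 8080 nM, and compound 3 `Cc1ccccc1Nc1nc(Nc2ccc(N3CCNCC3)cn2)ncc1Cl` gives 7870 nM. Compound 3 thus shares the low end of this small set with compound 2. Adding a ring to the core of compound 1 produced modest steps: a 2.5-fold lower number from compound 1 to compound 2 (0.40 log units; beyond the scatter) and a 2.6-fold lower number from compound 1 to compound 3 (0.41 log units; beyond the scatter).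

Compound 4 `Cc1ccccc1Nc1nc(Nc2ccc(N3CCCCC3)cn2)ncc1Cl` has not yet been measured. It differs from compound 3 as follows: piperidin-1-yl in place of piperazin-1-yl on an aromatic carbon. Put simply, piperidin-1-yl stands in place of piperazin-1-yl on an aromatic carbon. For the measured compounds named here, no measured compound carries piperidin-1-yl, so the evidence is indirect. The closest guide is a 1.0-fold lower number from compound 2 to compound 3 (0.01 log units; within the scatter), where hydrogen replaces methyl on an amine nitrogen in the ring and the value stays within the scatter. No step beyond the scatter is therefore expected in this assay, though the uncertainty is wide. The estimated change is a 1.0-fold higher number from compound 3 to compound 4 (0.01 log units; within the scatter). Compound 4 is expected to give 8000 nM, with an estimated range of 3500 nM to 20000 nM.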

Compound 4, concentration for 50% growth inhibition: > 100000 nM
Compound 4 was reported as a limit; the forecaster's own chance of this, stated with the estimate: 10%; middle value at least 12-fold (1.09 log units) from the limit.
By their numbers in this assay, from the lowest: compounds 3 and 2 (each within the scatter of the next); then compound 1. At a limit, above all of these: compound 4.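

The reading for compound 4 in this assay is a limit of the assay, not a number: the limit of > 100000 nM in this assay, at which 1 of the 4 values shown sits. Whether the second ring nitrogen of the piperazin-1-yl group carried methyl or hydrogen made no difference beyond the scatter, yet replacing that nitrogen with carbon gives an at least 12-fold higher number from compound 3 to compound 4 (1.10 log units; beyond the scatter) and an at least 12-fold higher number from compound 2 to compound 4 (1.09 log units; beyond the scatter), so at this position the nitrogen itself matters far more than its methyl. Nor does a six-membered ring here help by itself: piperidin-1-yl in place of hydrogen gives an at least 4.9-fold higher number from compound 1 to compound 4 (0.69 log units; beyond the scatter), the opposite direction to both piperazin-1-yl compounds.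

The compounds shown leave open whether an oxygen in that ring place, as in morpholin-4-yl, or an open-chain amine would behave like piperazin-1-yl or like piperidin-1-yl.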